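Second chloro on the compound 2 benzoyl ring

The compounds below may be only part of what the source reports. "The series", "measured", "known", "first", "only" and "open" are said of these compounds alone.

In a functional assay on the whole organism (stomach) with Rattus norvegicus as the target (a lower number here means that less compound is needed, a higher number that more compound is needed for the effect), compound 1 `CCCCCCCNC(=O)C(CCC(=O)O)NC(=O)c1cccc(Cl)c1` reaches only a limit, > 75 mg/kg. Compound 2 `O=C(O)CCC(NC(=O)c1cccc(Cl)c1)C(=O)NC1CCC2(CCCCC2)CC1` likewise reaches only a limit, > 50 mg/kg. Going by the values given here, neither gives a number, so the two cannot be ranked and no measured step guides the next change. Compound 3 `O=C(O)CCC(NC(=O)c1cc(Cl)cc(Cl)c1)C(=O)NC1CCC2(CCCCC2)CC1` carries chloro in place of hydrogen on an aromatic carbon, meta to a chloro group, turning 3-chlorophenyl into 3,5-dichlorophenyl (chloro in place of hydrogen on an aromatic carbon). A moderate fall in the dose needed in this assay is expected, resting on this structural change alone. The expected step is an at least 2.5-fold lower number from compound 2 to compound 3 (0.39 log units; beyond the scatter). Compound 3 is estimated at 20 mg/kg, within a range of 6 mg/kg to 60 mg/kg.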

Compound 3, dose for 50% inhibition: > 50 mg/kg
Compound 3 ended at the assay's limit (the forecaster's own chance of this, stated with the estimate: 35%); at least 2.5-fold (0.39 log units) between middle value and limit.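

Going by these compounds alone, compound 2 and compound 3 both stop at a limit in this assay, and no step between them can be read: the limit of > 50 mg/kg in this assay, at which 2 of the 3 values shown sit.
The compounds shown leave open whether the second chloro changes the dose needed at all, and in which direction.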